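Compound 3 to compound 4: changing the aryl group

A few compounds are considered here, and "the series" means these few. Any claim that something is new, unique, unknown or untested is made for them only; others in the source may bear on it.

Measured in a functional assay on CCRF-CEM cells (Homo sapiens) for antiproliferative activity; a lower number here means a stronger inhibitor, a higher number a weaker inhibitor:
compound 1 `COc1cc(C(=O)c2sc(-c3ccc(I)cc3)cc2N)cc(OC)c1OC`: 150 nM
compound 2 `COc1cc(C(=O)c2sc(-c3ccccc3)cc2N)cc(OC)c1OC`: 4.5 nM
compound 3 `COc1cc(C(=O)c2sc(-c3ccc(Cl)c(Cl)c3)cc2N)cc(OC)c1OC`: 290 nM

Compound 3 stands at the high end of these numbers. Its nearest neighbour is reached by a 1.9-fold higher number from compound 1 to compound 3 (0.29 log units; within the scatter), its furthest by a 64-fold higher number from compound 2 to compound 3 (1.81 log units; beyond the scatter). Next comes compound 4 `COc1cccc(-c2cc(N)c(C(=O)c3cc(OC)c(OC)c(OC)c3)s2)c1`, with 3-methoxyphenyl in place of 3,4-dichlorophenyl on an aromatic carbon next to the ring sulfur (3-methoxyphenyl in place of 3,4-dichlorophenyl on an aromatic carbon).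

The steps of a 64-fold higher number from compound 2 to compound 3 (1.81 log units; beyond the scatter) and a 33-fold lower number from compound 1 to compound 2 (1.52 log units; beyond the scatter) are both large, and both involve removing or adding halogen on the phenyl. Among the measured compounds shown here, no methoxy-bearing compound has been measured, so the guide is weak. A moderate step to a lower number in this assay is expected, stopping short of compound 2. The expected change is a 7.3-fold lower number from compound 3 to compound 4 (0.86 log units; beyond the scatter). For compound 4 the estimated value is 40 nM, within an expected range of 8 nM to 200 nM.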

Compound 4, half-maximal inhibitory concentration: 16 nM
Compound 4: middle estimate off by 2.5-fold (0.40 log units), on the high side; the measured number falls inside the stated range.
By their numbers in this assay, from the lowest: compound 2; then compound 4; then compounds 1 and 3 (each within the scatter of the next).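

In this assay the 3-methoxyphenyl group shows that a substituted phenyl at this position can retain a low number, unlike 3,4-dichlorophenyl (an 18-fold lower number from compound 3 to compound 4 (1.26 log units; beyond the scatter)) and 4-iodophenyl (a 9.4-fold lower number from compound 1 to compound 4 (0.97 log units; beyond the scatter)). Even so, the methoxy group does not match the unsubstituted phenyl (a 3.6-fold higher number from compound 2 to compound 4 (0.55 log units; beyond the scatter)), so among these compounds every substituent tried gives a higher number than hydrogen. Nothing at hand explains these differences.

On these data alone, whether the methoxy group itself or its place on the phenyl sets the result remains open. As far as these compounds go, how a hydroxy or an ethoxy group on the phenyl would compare also remains open.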